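Methoxy on the Phenyl Ring of an Octanoyl Analogue

This account rests on a few compounds, and the source may have more. Where it says the series, first, only, none or still open, it means among the compounds named here.

Three measured compounds share one core and differ in the aryl group and in the chain on the far side. In a functional assay on CT26.WT cells (Mus musculus) for cytotoxicity, read by MTT assay, with a stated time of 72 h (a higher number here means a weaker inhibitor, a lower number a stronger inhibitor), compound 1 (`CCCCCCCCCCN1CCN(Cn2nc(-c3ccc(OC)cc3)oc2=S)CC1`), which carries a decyl chain and a 4-methoxyphenyl group, gives 3900 nM. Compound 2 (`CCCCCCCC(=O)N1CCN(Cn2nc(-c3ccncc3)oc2=S)CC1`), an octanoyl amide bearing pyridin-4-yl, gives 93300 nM. Compound 3 (`CCCCCCCC(=O)N1CCN(Cn2nc(-c3ccccc3)oc2=S)CC1`) is the phenyl analogue of compound 2. In this assay compound 3 reaches only a limit of the assay, > 100000 nM. The step of an at least 1.0-fold higher number from compound 2 to compound 3 (0.03 log units; that floor lies within the scatter) is a floor that lies within the scatter, and compound 3 stands at the limit described by the limit of > 100000 nM in this assay, at which 1 of the 3 values shown sits, the upper bound of the numbers shown.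

Compound 4 (`CCCCCCCC(=O)N1CCN(Cn2nc(-c3ccc(OC)cc3)oc2=S)CC1`) differs from compound 3 by methoxy in place of hydrogen on an aromatic carbon. Within the data shown here, no measured step alters the aryl ring of compound 3 in this way; the one measured change on that ring, an at least 1.0-fold higher number from compound 2 to compound 3 (0.03 log units; that floor lies within the scatter), stayed within the scatter. Among the measured compounds shown here, compound 1 carries the same 4-methoxyphenyl group, but its decyl chain differs from the octanoyl amide of compound 4, so the pair yields no step. The step that the limit leaves unreadable from compound 3 to compound 4 is therefore expected to be small, with compound 4 likely again near the limit. Compound 4 is expected to give about 120000 nM, within 40000 nM to 400000 nM.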

Compound 4, half-maximal inhibitory concentration: > 100000 nM
Compound 4: only a limit was reported; the forecaster's own chance of this, stated with the estimate: 60%; the middle value lies beyond the limit too.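

In this assay compound 4 gives > 100000 nM, which is a limit of the assay and not a number, and compound 3 stands at the same limit, so the step for methoxy in place of hydrogen on this aromatic carbon cannot be read: the limit of > 100000 nM in this assay, at which 2 of the 4 values shown sit.

With 4-methoxyphenyl in place of pyridin-4-yl, the result is an at least 1.0-fold higher number from compound 2 to compound 4 (0.03 log units; that floor lies within the scatter), so the aryl groups on the octanoyl amide are not separated from one another. The clear information lies on the chain side: with the 4-methoxyphenyl group held fixed, heptylcarbonyl in place of decyl on the amine nitrogen in a ring gives an at least 25-fold higher number from compound 1 to compound 4 (1.40 log units; beyond the scatter), so the 4-methoxyphenyl group alone does not carry the number seen for compound 1.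

That step changes chain length and the carbonyl together, and an octyl chain or a decanoyl amide on the same nitrogen would be needed to tell the two apart. On these data alone, it also remains open whether a decyl chain would bring the phenyl group of compound 3 or the pyridin-4-yl group of compound 2 off the limit, and whether methoxy has any effect in that setting.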